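The source may report more compounds than this note shows. Statements on the series, on what has been measured and on what is new or still open speak of the compounds shown alone.

Measured so far:
Compound 1 `CC1CCN(c2nc(C(F)F)ccc2CNC(=O)C(C)c2ccc(NS(C)(=O)=O)c(F)c2)CC1` gives 1 nM in an assay on CHO cells for antagonist activity at transient receptor potential cation channel subfamily V member 1 (Homo sapiens), read by FLIPR; on this read-out lower numbers stand for stronger inhibition and higher numbers for weaker inhibition.
Compound 2 `CC1CCN(c2nc(C(F)(F)Cl)ccc2CNC(=O)C(C)c2ccc(NS(C)(=O)=O)c(F)c2)CC1` gives 0.3 nM in this assay.
Compound 3 `CC1CCN(c2nc(C3CC3)ccc2CNC(=O)C(C)c2ccc(NS(C)(=O)=O)c(F)c2)CC1` gives 0.9 nM in this assay.

All three share one core and differ only in the group that sits on the ring carbon next to the ring nitrogen. Among these three numbers compound 3 stands second highest: its nearest neighbour is compound 1, and the step of a 1.1-fold lower number from compound 1 to compound 3 (0.05 log units; within the scatter) falls within the usual scatter, so the two cannot be told apart. Compound 2 lies further away, with a 3.0-fold higher number from compound 2 to compound 3 (0.48 log units; beyond the scatter) reaching beyond the scatter.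

Compound 4 `CC1CCN(c2nc(-c3ccc(F)cc3)ccc2CNC(=O)C(C)c2ccc(NS(C)(=O)=O)c(F)c2)CC1` carries a change at the same place: 4-fluorophenyl in place of cyclopropyl on an aromatic carbon. The measured steps at this position all swap one small group for another of similar size, and the difference between them stays modest, as a 3.3-fold lower number from compound 1 to compound 2 (0.52 log units; beyond the scatter) shows. None of them puts an aromatic ring there, so they give no direct guide for a 4-fluorophenyl group. Without such a guide, the expected step of a 1.3-fold higher number from compound 3 to compound 4 (0.12 log units; within the scatter) is essentially none beyond the scatter, with a wide band to allow for the larger group. In this assay compound 4 is therefore estimated at 1.2 nM, most likely between 0.3 nM and 5 nM.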

Compound 4, inhibition constant: 59 nM
Beside the measured number, compound 4's estimate is 49-fold (1.69 log units) below it; the whole stated range lies below it.
By their numbers in this assay, from the lowest: compound 2; then compounds 3 and 1 (each within the scatter of the next); then compound 4.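

Compounds 1, 2 and 3 suggested a forgiving position, since difluoromethyl, chloro(difluoro)methyl and cyclopropyl differ by modest steps at most in this assay, but 4-fluorophenyl, with 7 heavy atoms where cyclopropyl has 3, shows that this tolerance has a limit, giving a 66-fold higher number from compound 3 to compound 4 (1.82 log units; beyond the scatter). The loss does not depend on which small group serves as the reference: the change gives a 200-fold higher number from compound 2 to compound 4 (2.29 log units; beyond the scatter) and a 59-fold higher number from compound 1 to compound 4 (1.77 log units; beyond the scatter), both large steps. Nothing measured here says what lies behind this loss.

For the compounds shown here, only one aromatic group stands at this place, so it remains open whether plain phenyl, without the fluorine, would give a similar number, or whether the loss is tied to this particular group. Going by these compounds, it is also open where a longer chain such as n-butyl, or an amine such as dimethylamino, would land relative to the small groups and 4-fluorophenyl, which would show whether the number rises gradually or abruptly as the group changes.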